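The source may hold more compounds than are shown below. What is called first, only, known or untested is meant among the compounds shown, and "the series" means these compounds.

In a physicochemical assay (on this read-out lower numbers stand for stronger inhibition and higher numbers for weaker inhibition), compound 1 (`COc1cc(C=C(C(=O)/C=C/c2ccc(N(C)C)cc2)C(=O)/C=C/c2ccc(N(C)C)cc2)ccc1O`) gives 45 ug/mL and compound 2 (`COc1ccc(-n2nc(/C=C/c3ccc(N(C)C)cc3)cc2/C=C/c2ccc(N(C)C)cc2)cc1`) gives 79.6 ug/mL on the data so far. These two numbers lie within the scatter of each other, so compound 2 stands level with compound 1. Compound 3 (`CN(C)c1ccc(/C=C/c2cc(/C=C/c3ccc(N(C)C)cc3)n(-c3ccccc3)n2)cc1`) departs from compound 2 by one change, hydrogen in place of methoxy on an aromatic carbon with hydrogen in place of methoxy on an aromatic carbon, para to a large group, which reads as 4-methoxyphenyl to phenyl. Among the compounds with values here, no measured pair shows this change, so the data do not size it. In this assay no step beyond the scatter is expected, in either direction. The estimated step of a 1.1-fold lower number from compound 2 to compound 3 (0.03 log units; within the scatter) is expected to stay within the scatter. This expectation rests on compound 2 at 79.6 ug/mL as the closest measured structure. For compound 3 the expected value is 75 ug/mL within an estimated range from 35 ug/mL to 160 ug/mL on this read-out.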

Compound 3, half-maximal inhibitory concentration: 72.4 ug/mL
Beside the measured number, compound 3's estimate is 1.0-fold (0.02 log units) above it, and the stated range covers the measured number.
By their numbers in this assay, from the lowest: compounds 1, 3 and 2 (each within the scatter of the next).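

In this assay, taking the methoxy off the six-membered aromatic ring of carbon only gives a 1.1-fold lower number from compound 2 to compound 3 (0.04 log units; within the scatter), the first measured read on 4-methoxyphenyl to phenyl in this series. At this place, para to a large group, the methoxy can therefore be replaced by hydrogen with no step beyond the scatter, so this read-out does not depend on that group in this pair. Nothing on hand accounts for the flat result, and it rests on this single pair.

From the compounds shown here alone, whether this position stays as flat with a different kind of group, such as a carboxylic acid, a primary amine or a longer alkoxy chain, remains open. Also open, going by these compounds, is whether the same change gives so small a step on another core.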